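Lipophilicity notes on an imidazolium oxime series

The source may report more compounds than this note shows. Statements on the series, on what has been measured and on what is new or still open speak of the compounds shown alone.

Measured so far:
- compound 1, `C[n+]1ccn(COCCCCCl)c1/C=N/O`: -1.47
- compound 2, `C[n+]1ccn(CCS(C)(=O)=O)c1/C=N/O`: -3.5

In a physicochemical assay for lipophilicity (on this read-out lower numbers stand for lower lipophilicity and higher numbers for higher lipophilicity), compound 1 gives -1.47, the higher of the two numbers recorded. In this assay compound 2 gives -3.5, a number well beyond the scatter below compound 1. For the measured compounds named here, no single-point step between measured compounds is available, so the pair shows only that the two readings lie far apart.

Compound 3, `C[n+]1ccn(COCCS(C)(=O)=O)c1/C=N/O`, has not yet been measured in this assay. Relative to compound 1 the change is methylsulfonyl in place of 2-chloroethyl on a saturated chain carbon, two bonds along the chain from an oxygen on a saturated carbon. Compound 2, which also carries a methylsulfonyl group, sits far below compound 1 in this assay, and a downward step of similar kind is expected here, beyond the scatter. For compound 3 in this assay the estimate is -3.1, with a range from -3.8 to -2.4, an expected step of a number 1.63 log units lower from compound 1 to compound 3 (beyond the scatter).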

Compound 3, distribution coefficient: < -3.3
Compound 3: no number, only a limit; the forecaster's own chance of this, stated with the estimate: 5%; middle value at least 0.20 log units away from the limit.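

In this assay compound 3 gives < -3.3, which is a limit of the assay and not a number. Methylsulfonyl in place of 2-chloroethyl on a saturated chain carbon, two bonds along the chain from an oxygen on a saturated carbon, gives the series its first step at a single place: a number at least 1.83 log units lower from compound 1 to compound 3 (beyond the scatter). Only the minimum size of this step is fixed, and its full size cannot be read, because the reading for compound 3 lies at the limit: the limit of < -3.3 in this assay, at which 1 of the 3 values shown sits.

The compounds shown leave open how much of the step comes from losing the chlorine and how much from gaining the methylsulfonyl group. Also open, on these data alone, is how an unsubstituted longer chain, an amine or a carboxylic acid at this position would read in this assay.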